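This account rests on a few compounds, and the source may have more. Where it says the series, first, only, none or still open, it means among the compounds named here.

Three compounds share one core, an acrylamide joined to a sulfonamide, and have been tested in a functional assay on B16-F10 cells (Mus musculus) for antiproliferative activity, read by ELISA and MTT assay, with a stated time of 48 h; on this read-out lower numbers stand for stronger inhibition and higher numbers for weaker inhibition. Compound 1 `O=C(/C=C/c1ccccc1)NS(=O)(=O)c1ccccc1` gives 3.5 ug/mL. Compound 2 `Cc1ccc(S(=O)(=O)NC(=O)/C=C/c2ccccc2)cc1` gives 13.8 ug/mL, the highest number of the three: the step between the first two compounds reads a 3.9-fold higher number from compound 1 to compound 2 (0.60 log units; beyond the scatter), and compound 3 `O=C(/C=C/c1ccccc1)NS(=O)(=O)c1ccc(F)cc1` gives 2.1 ug/mL, so that the other step reads a 6.6-fold lower number from compound 2 to compound 3 (0.82 log units; beyond the scatter). Compound 3 and compound 1 lie within the scatter of each other, as a 1.7-fold lower number from compound 1 to compound 3 (0.22 log units; within the scatter) shows.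

Compound 4 `Cc1ccc(S(=O)(=O)NC(=O)/C=C/c2ccc(Br)cc2)cc1` differs from compound 2 by bromo in place of hydrogen on an aromatic carbon. All three measured steps change a group on the ring that carries the sulfonyl, not the ring at the far end of the acrylamide where the bromo enters, so none bears directly on this change. For the measured compounds named here, the only halogen step measured, from compound 1 to compound 3, stayed within the scatter. In this assay compound 4 is therefore expected to show little change, a 1.4-fold lower number from compound 2 to compound 4 (0.14 log units; within the scatter), with an estimated value of 10 ug/mL in the range 4 ug/mL to 30 ug/mL.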

Compound 4, half-maximal inhibitory concentration: 12.1 ug/mL
Estimate against measurement, compound 4: 1.2-fold (0.08 log units) below; the range from low to high includes it.
By their numbers in this assay, from the lowest: compounds 3 and 1 (each within the scatter of the next); then compounds 4 and 2 (each within the scatter of the next).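

In this assay, the change from phenyl to 4-bromophenyl gives a 1.1-fold lower number from compound 2 to compound 4 (0.06 log units; within the scatter), the first step shown on the aromatic ring that does not carry the sulfonyl. Adding a bromo at this position leaves the number of compound 2 indistinguishable from the usual scatter, whereas the methyl change on the sulfonyl-bearing ring gave a 3.9-fold higher number from compound 1 to compound 2 (0.60 log units; beyond the scatter). Nothing measured here explains why the bromo makes so little difference.

As far as these compounds go, this single step comes from the methyl-bearing compound 2, so it remains open whether bromo would behave the same way on compound 1, which has no methyl. From the compounds shown here alone, it also remains open whether a quite different group at this position, such as an amine, a carboxylic acid or a methoxy, would shift the number beyond the scatter.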